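A Sulfonamide Series: Changing the Aniline Substituents

A few compounds are considered here, and "the series" means these few. Any claim that something is new, unique, unknown or untested is made for them only; others in the source may bear on it.

Compound 1 `O=S(=O)(Nc1cccc(Cl)c1)c1ccc(-c2cnc(C3CC3)o2)cc1`: 477 nM
Compound 2 `O=S(=O)(Nc1ccc(Br)c(Cl)c1)c1ccc(-c2cnc(C3CC3)o2)cc1`: 491 nM
Compound 3 `O=S(=O)(Nc1ccc(I)c(Cl)c1)c1ccc(-c2cnc(C3CC3)o2)cc1`: 1010 nM

In a functional assay on cells (leukaemia cell line, Homo sapiens) for inhibition, read by sulforhodamine B assay, with a stated time of 48 h (a lower number here means a stronger inhibitor of growth, a higher number a weaker inhibitor of growth), compound 1 gives the lowest of the three numbers, but compound 2 lies within the scatter of it, so no order between those two can be claimed; only compound 3 lies beyond it. The untested compound 4 `Cc1cc(F)cc(NS(=O)(=O)c2ccc(-c3cnc(C4CC4)o3)cc2)c1` differs from compound 1 by 3-fluoro-5-methylphenyl in place of 3-chlorophenyl on a sulfonamide nitrogen. For the measured compounds named here, no measured step replaces this group: a 1.0-fold higher number from compound 1 to compound 2 (0.01 log units; within the scatter) and a 2.1-fold higher number from compound 1 to compound 3 (0.33 log units; beyond the scatter) each add a halogen on an aromatic carbon and keep the chloro. Those steps show that changes on this ring move the number modestly at most. A step of at most modest size, or none beyond the scatter, is expected, a 1.2-fold higher number from compound 1 to compound 4 (0.06 log units; within the scatter). Compound 4 is therefore estimated at 550 nM, within 230 nM to 1300 nM.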

Compound 4, concentration for 50% growth inhibition: 138 nM
For compound 4 the middle estimate is 4.0-fold (0.60 log units) above the measured one; measured number outside the range, below it.
By their numbers in this assay, from the lowest: compound 4; then compounds 1 and 2 (each within the scatter of the next); then compound 3.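

In this assay the 3-fluoro-5-methylphenyl group on the sulfonamide nitrogen gives a 3.5-fold lower number from compound 1 to compound 4 (0.54 log units; beyond the scatter) and, unlike the added halogens, moves the number down, so this position can gain as well as lose. The same group gives a 3.6-fold lower number from compound 2 to compound 4 (0.55 log units; beyond the scatter) and a 7.3-fold lower number from compound 3 to compound 4 (0.86 log units; beyond the scatter) when it replaces the two rings carrying a pair of halogens. Nothing measured here gives a reason for these drops.

From the compounds shown here alone, whether the fluoro, the methyl or the loss of the chloro carries the change stays open. A 3-methylphenyl or a 3-fluorophenyl group on the same nitrogen would begin to separate them.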